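Methyl in place of hydrogen on compound 2

This account rests on a few compounds, and the source may have more. Where it says the series, first, only, none or still open, it means among the compounds named here.

Compound 2 `NC(=O)c1nn(C2O[C@H](CO)[C@@H](O)[C@H]2O)cc1[N+](=O)[O-]` is the starting point of this step. In a functional assay on L1210 cells (Mus musculus) (a higher number here means a weaker inhibitor, a lower number a stronger inhibitor), compound 2 gives only a limit, > 1730 uM. Compound 1 `NC(=O)c1ccn(C2O[C@H](CO)[C@@H](O)[C@H]2O)n1` likewise gives only a limit in this assay, > 1030 uM. Compound 3 `NC(=O)c1nn(C2O[C@H](CO)[C@@H](O)[C@H]2O)cc1Br` also gives a limit rather than a number in this assay, > 1550 uM. Compound 2 thus stands at a limit, and the two further values shown are limits as well. The change to compound 4 `Cc1c([N+](=O)[O-])c(C(N)=O)nn1C1O[C@H](CO)[C@@H](O)[C@H]1O` is methyl in place of hydrogen on an aromatic carbon. Within the data shown here, the measured steps a step that the two limits leave unreadable from compound 1 to compound 2, a step that the two limits leave unreadable from compound 1 to compound 3 and a step that the two limits leave unreadable from compound 2 to compound 3 are the only comparisons available, and each joins two limits, so no size can be read from them; the evidence consists of the limit of > 1030 uM in this assay, at which 1 of the 3 values shown sits, the limit of > 1550 uM in this assay, at which 1 of the 3 values shown sits, and (the limit of > 1730 uM in this assay, at which 1 of the 3 values shown sits). Among the measured compounds shown here, no measured step therefore gives a direction for this assay, and nothing points to a shift beyond the scatter. For compound 4 in this assay the estimate is 2000 uM, between 800 uM and 5000 uM. The step that the limit leaves unreadable from compound 2 to compound 4 is expected to be none beyond the scatter, with another limit the most probable outcome.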

Compound 4, concentration for 50% inhibition: > 1650 uM
Compound 4 was reported as a limit; the forecaster's own chance of this, stated with the estimate: 85%; the middle value lies beyond the limit too.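

In this assay compound 4 gives only a limit, > 1650 uM. Compound 2 is also a limit, and the step between compound 2 and compound 4 cannot be read. The compounds shown leave open at what concentration any of them inhibits, and whether methyl in place of hydrogen changes it.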